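The source may report more compounds than this note shows. Statements on the series, on what has been measured and on what is new or still open speak of the compounds shown alone.

Compound 1 `O=C(O)CC[C@H](NC(=O)CN(c1nc(Cl)nc2[nH]cnc12)C1CC1)C(=O)O` gives 30.1% in a functional assay on the whole organism (Tail, strain ICR) with Mus musculus as the target, in the tail flick test, with a stated time of 120 min, at a dose of 25 umol/kg by the oral route; a higher number here means a stronger effect of the compound at the dose given, a lower number a weaker effect. Among the compounds with values here, compound 2 `CC(C)C[C@H](NC(=O)CN(c1nc(Cl)nc2[nH]cnc12)C1CC1)C(=O)O` gives 18.7% in this assay, the lowest of the two numbers, the only measured step being a number 11.4 percentage points lower from compound 1 to compound 2 (beyond the scatter). Compound 3 `NC(=O)CC[C@H](NC(=O)CN(c1nc(Cl)nc2[nH]cnc12)C1CC1)C(=O)O` differs from compound 2 by carbamoylmethyl in place of isopropyl on a saturated chain carbon, two bonds along the chain from an amide-type nitrogen and a carbonyl carbon. Within the data shown here, the one step that bears on this change is a number 11.4 percentage points lower from compound 1 to compound 2 (beyond the scatter), where isopropyl entered in place of carboxymethyl and the read-out fell; carbamoylmethyl stands nearer to carboxymethyl than isopropyl does, so an upward step of a number 8.3 percentage points higher from compound 2 to compound 3 (within the scatter) is expected, with uncertainty since neither measured compound holds this group. Compound 3 is therefore estimated at 27%, within 15% to 40%.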

Compound 3, a percentage reported as activity, at one dose (the size of the read-out at that dose, not a potency): 17.8%
Beside the measured number, compound 3's estimate is 9.2 percentage points above it; the measured number falls inside the stated range.
By their numbers in this assay, from the lowest: compounds 3 and 2 (each within the scatter of the next); then compound 1.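

In this assay, carbamoylmethyl in place of isopropyl on this saturated chain carbon gives a number 0.9 percentage points lower from compound 2 to compound 3 (within the scatter), so the two side chains cannot be separated at this dose. Amino in place of hydroxy on the carbonyl carbon gives a number 12.3 percentage points lower from compound 1 to compound 3 (beyond the scatter), so among these three compounds compound 1 alone stands apart, and the change from its carboxymethyl to carbamoylmethyl is enough to produce that gap. No measured evidence explains this result.

On these data alone, whether an amine at this position, or a longer chain ending in a carboxylic acid, would match compound 1 remains open.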